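A few compounds are considered here, and "the series" means these few. Any claim that something is new, unique, unknown or untested is made for them only; others in the source may bear on it.

Three compounds share one core: compound 1 `CCNc1cc(Oc2ccc(NC(=O)Nc3cccc(C(F)(F)F)c3)cc2)ncn1`, compound 2 `CCCNc1cc(Oc2ccc(NC(=O)Nc3cccc(C(F)(F)F)c3)cc2)ncn1` and compound 3 `CC(C)CNc1cc(Oc2ccc(NC(=O)Nc3cccc(C(F)(F)F)c3)cc2)ncn1`. In an assay on isolated protein for inhibition of serine/threonine-protein kinase TNNI3K (Homo sapiens) (on this read-out higher numbers stand for weaker inhibition and lower numbers for stronger inhibition), compound 1 gives 25 nM, compound 2 gives 32 nM and compound 3 gives 50 nM, the highest of the three numbers, though a 2.0-fold higher number from compound 1 to compound 3 (0.30 log units; within the scatter), a 1.6-fold higher number from compound 2 to compound 3 (0.19 log units; within the scatter) and a 1.3-fold higher number from compound 1 to compound 2 (0.11 log units; within the scatter) all stay within the scatter. Compound 4 `O=C(Nc1ccc(Oc2cc(NCCO)ncn2)cc1)Nc1cccc(C(F)(F)F)c1` differs from compound 3 by hydroxymethyl in place of isopropyl on a saturated chain carbon bound to a nitrogen on an aromatic ring. Going by the values given here, the measured steps bear only on the size of the alkyl chain on the ring nitrogen, and none of them moves the number beyond the scatter; no measured pair tests a hydroxyl group. Compound 4 is therefore expected to show a 1.4-fold lower number from compound 3 to compound 4 (0.15 log units; within the scatter), with no clear direction. For compound 4 the estimate is 35 nM, between 12 nM and 100 nM.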

Compound 4, half-maximal inhibitory concentration: 32 nM
The estimate for compound 4 lay 1.1-fold (0.04 log units) above the measured number; measured number inside the range.
By their numbers in this assay, from the lowest: compounds 1, 2, 4 and 3 (each within the scatter of the next).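

Compound 4 is the first of these compounds to carry a hydroxy group on the chain, and the change gives a 1.6-fold lower number from compound 3 to compound 4 (0.19 log units; within the scatter), while the two narrower comparisons give no change at the digits printed from compound 2 to compound 4 (within the scatter) and a 1.3-fold higher number from compound 1 to compound 4 (0.11 log units; within the scatter). This position therefore takes a hydrogen-bond donor and acceptor in this assay with no step beyond the scatter. No evidence is available to explain this result.

On these data alone, an amine or a carboxylic acid at the end of the chain remains open, as does a methoxy group in place of the hydroxy group. As far as these compounds go, a longer chain carrying the hydroxy group also remains untested by these four compounds.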